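Benzofuran for benzothiophene on the amide of compound 3

This account rests on a few compounds, and the source may have more. Where it says the series, first, only, none or still open, it means among the compounds named here.

Working notes on the series. Three compounds share one core and differ only in the aryl group on the amide carbonyl. Compound 1 `CCc1ccc(C(=O)NC[C@H]2c3[nH]c4ccccc4c3C[C@H]3[C@H]4c5[nH]c6ccccc6c5C[C@@H]([C@H](C#N)N23)N4C)cc1` carries a 4-ethylphenyl group; in a functional assay on A2780 cells (Homo sapiens) for cytotoxicity, read by MTT assay, with a stated time of 72 h (on this read-out lower numbers stand for stronger inhibition and higher numbers for weaker inhibition), compound 1 gives 670 nM. Compound 2 `CN1[C@@H]2c3[nH]c4ccccc4c3C[C@H]1[C@H](C#N)N1[C@@H](CNC(=O)c3ccc4ccccc4c3)c3[nH]c4ccccc4c3C[C@@H]21` carries a naphthalen-2-yl group, and in this assay compound 2 gives 1030 nM; the step of a 1.5-fold higher number from compound 1 to compound 2 (0.19 log units; within the scatter) stays within the scatter. Compound 3 `CN1[C@@H]2c3[nH]c4ccccc4c3C[C@H]1[C@H](C#N)N1[C@@H](CNC(=O)c3cc4ccccc4s3)c3[nH]c4ccccc4c3C[C@@H]21` carries a 1-benzothiophen-2-yl group, and in this assay compound 3 gives 20 nM, the strongest of the three: the steps of a 34-fold lower number from compound 1 to compound 3 (1.53 log units; beyond the scatter) and a 52-fold lower number from compound 2 to compound 3 (1.71 log units; beyond the scatter) both lie well beyond the scatter.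

Compound 4 `CN1[C@@H]2c3[nH]c4ccccc4c3C[C@H]1[C@H](C#N)N1[C@@H](CNC(=O)c3cc4ccccc4o3)c3[nH]c4ccccc4c3C[C@@H]21` is not yet measured. The change from compound 3 is 1-benzofuran-2-yl in place of 1-benzothiophen-2-yl on a carbonyl carbon. For the measured compounds named here, no measured step covers this exchange of the ring heteroatom; the two large steps leading to compound 3 only show that the bicyclic five-membered ring outperforms the phenyl and naphthalene groups, and they say nothing about whether sulfur or oxygen carries that gain. The expectation for compound 4 is therefore a number not far from compound 3, with a modest loss allowed because the value 20 nM of compound 3 stands alone at the low end. The estimated step is a 3.0-fold higher number from compound 3 to compound 4 (0.48 log units; beyond the scatter). For compound 4 in this assay the estimate is 60 nM, ranging from 15 nM to 300 nM.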

Compound 4, half-maximal inhibitory concentration: 230 nM
Compound 4: the middle estimate sits 3.8-fold (0.58 log units) below what was measured; low and high end bracket the measured number.
By their numbers in this assay, from the lowest: compound 3; then compound 4; then compounds 1 and 2 (each within the scatter of the next).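

In this assay the ring heteroatom of the group on the amide carbonyl matters: oxygen in place of sulfur, with the rest of the structure unchanged, gives a 12-fold higher number from compound 3 to compound 4 (1.06 log units; beyond the scatter). The low number of compound 3 therefore belongs to the 1-benzothiophen-2-yl group specifically and is not shared in full by 1-benzofuran-2-yl, even though both groups have the same counts of heavy atoms, aromatic rings, hydrogen-bond donors and hydrogen-bond acceptors. Part of the advantage over the other two groups remains, but it is smaller, with a 4.5-fold lower number from compound 2 to compound 4 (0.65 log units; beyond the scatter) and a 2.9-fold lower number from compound 1 to compound 4 (0.46 log units; beyond the scatter), so among these four compounds the largest gain at this carbonyl carbon requires the sulfur-containing group.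

Nothing available explains why the exchange of sulfur for oxygen carries this cost. Also open, from the compounds shown here alone, is how 1H-indol-2-yl, with a ring nitrogen bearing hydrogen in the heteroatom's place, would compare on this amide, and whether a chlorine or a methoxy group on the 1-benzothiophen-2-yl group would keep the number of compound 3.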